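This account rests on a few compounds, and the source may have more. Where it says the series, first, only, none or still open, it means among the compounds named here.

Among the compounds with values here, compound 2 `CCCCSc1nsnc1C1CN2CCC[C@H]1C2` carries a single defined centre and gives 0.007 mg/kg in a functional assay on the whole organism for inhibition, with Rattus norvegicus as the target (on this read-out lower numbers stand for an effect already at smaller amounts and higher numbers for an effect only at larger amounts of compound), the only full number in this set. Compound 1 `CCCCSc1nsnc1[C@@H]1CN2CCC[C@@H]1C2`, drawn with both ring centres defined, reaches only a limit in this assay, at > 3 mg/kg. The step of an at least 420-fold lower number from compound 1 to compound 2 (2.63 log units; beyond the scatter) is large, and part of it rests on the limit of > 3 mg/kg in this assay, at which 1 of the 2 values shown sits, and on the fact the fact that one of compounds 1 and 2 is drawn with a defined configuration and the other without, at the place where they differ that compound 2 leaves one centre open where compound 1 fixes it.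

Compound 3 `CCCCSc1nsnc1[C@@H]1CN2CCC[C@H]1C2` now fixes that open centre: the two compounds have the same atoms and bonds; at least one stereo element is drawn with a configuration in one of them and without one in the other: 1 of 3 stereo elements differ; a stereocentre at a saturated ring carbon is drawn without a configuration in compound 2 and S in compound 3. Within the data shown here, only the step from compound 1 to compound 2 bears on this, and it shows that the configuration at these ring centres decides the outcome. Since compound 3 is one of the forms held within compound 2, its number is expected close to that of compound 2, with the step of a 1.1-fold higher number from compound 2 to compound 3 (0.06 log units; within the scatter) estimated as small but uncertain. For compound 3 the estimate is 0.008 mg/kg, within 0.002 mg/kg to 0.1 mg/kg.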

Compound 3, dose for half-maximal effect: 0.018 mg/kg
For compound 3 the middle estimate is 2.3-fold (0.35 log units) below the measured one, and the stated range covers the measured number.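

In this assay, compound 1 and compound 3 have the same atoms and bonds and differ at one saturated ring carbon, so an at least 160-fold lower number from compound 1 to compound 3 (2.22 log units; beyond the scatter) ties a large change to that single centre, which compound 2 alone could not do. The value of compound 1, > 3 mg/kg, is a limit and not a number. Fixing the open centre also matters on a smaller scale, since a 2.6-fold higher number from compound 2 to compound 3 (0.41 log units; beyond the scatter) shows that the form with this centre defined does not simply match the drawing that leaves it open: the fact that one of compounds 2 and 3 is drawn with a defined configuration and the other without, at the place where they differ

On these data alone, all three compounds share the same side chain on the shared core, so the effect of a longer chain or an amine at that place remains open. A whole-organism read-out also cannot show whether the centre acts on the target itself or on how the compound behaves in the animal.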